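The compounds below may be only part of what the source reports. "The series", "measured", "known", "first", "only" and "open" are said of these compounds alone.

Measured so far in a physicochemical assay for solubility, measured as kinetic solubility; a higher number here means a more soluble compound, a lower number a less soluble compound:
compound 1 `Cc1cc(C)c(CN2CCc3c(Cl)cc([C@@H](CO)[C@@H]4CCCO4)c(Cl)c3C2=O)c(=O)[nH]1` gives 550000 nM;
compound 2 `Cc1cc(C)c(CN2CCc3c(Cl)cc([C@@H](C)CO)c(Cl)c3C2=O)c(=O)[nH]1` gives 143000 nM.

Compound 2 stands lowest of the two numbers: from compound 1 to compound 2 the change was a 3.8-fold lower number from compound 1 to compound 2 (0.59 log units; beyond the scatter). Compound 3 `Cc1cc(C)c(CN2CCc3c(Cl)cc([C@@H](CO)[C@H]4CCCO4)c(Cl)c3C2=O)c(=O)[nH]1` differs from compound 2 by a group of 8 heavy atoms (6 carbon, 2 oxygen; one five-membered non-aromatic ring with 1 hetero atom) in place of a group of 4 heavy atoms (3 carbon, 1 oxygen; no ring), on an aromatic carbon. This reverses the change that led from compound 1 to compound 2, so a rise of similar size is expected in this assay. The estimated step is a 3.5-fold higher number from compound 2 to compound 3 (0.54 log units; beyond the scatter), and compound 3 is expected to give about 500000 nM, within a range from 200000 nM to 1200000 nM.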

Compound 3, solubility: 576000 nM
For compound 3 the middle estimate is 1.2-fold (0.06 log units) below the measured one; the range from low to high includes it.
By their numbers in this assay, from the lowest: compound 2; then compounds 1 and 3 (each within the scatter of the next).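

In this assay the group with the five-membered ring, in place of 1-(hydroxymethyl)ethyl, goes with a higher number in both drawn configurations of its saturated ring carbon, now also (a 4.0-fold higher number from compound 2 to compound 3 (0.61 log units; beyond the scatter)). The two configurations give numbers within the scatter of each other (a 1.0-fold higher number from compound 1 to compound 3 (0.02 log units; within the scatter)). At this position, that stereocentre makes no readable difference in this assay, and the pair tests it alone: the fact that compounds 1 and 3 differ only in the configuration as drawn.

Still open, going by these compounds, is whether the ring itself is needed, which an open-chain methoxyethyl group or an amine at this position could test. On these data alone, the other stereocentre also stays the same in compound 1 and compound 3, so its configuration remains untested.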